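A few compounds are considered here, and "the series" means these few. Any claim that something is new, unique, unknown or untested is made for them only; others in the source may bear on it.

In a functional assay on A2780 cells (Homo sapiens) for inhibition, read by sulforhodamine B assay (a lower number here means a stronger inhibitor of growth, a higher number a weaker inhibitor of growth), compound 3 (`Oc1cccc2[nH]c(-c3ccc(-c4ccc(-c5ccc(C(F)(F)F)cc5)cc4)cc3)nc12`) gives 6100 nM and stands lowest of the three measured compounds. In this assay compound 2 (`Oc1cccc2[nH]c(-c3ccc(-c4ccc(-c5ccc(F)cc5)cc4)cc3)nc12`) gives 41200 nM and compound 1 (`FC(F)(F)c1ccc(-c2ccc(-c3ccc(-c4nc5ccccc5[nH]4)cc3)cc2)cc1`) gives 100000 nM as the highest number. Compound 4 (`CN(C)c1ccc(-c2ccc(-c3ccc(-c4nc5c(O)cccc5[nH]4)cc3)cc2)cc1`) is still unmeasured. It carries dimethylamino in place of trifluoromethyl on an aromatic carbon, para to a large group (dimethylamino in place of trifluoromethyl on an aromatic carbon). The closest evidence is trifluoromethyl in place of fluoro on an aromatic carbon, a modest change of a 6.8-fold lower number from compound 2 to compound 3 (0.83 log units; beyond the scatter) and thus a sign that this end group can shift the number. The hydroxy in place of hydrogen gave a large change of a 16-fold lower number from compound 1 to compound 3 (1.21 log units; beyond the scatter) and compound 4 keeps that hydroxy. Among the measured compounds shown here, no measured compound carries dimethylamino, so the direction is uncertain. For the measured compounds named here, the one swap seen between end groups left trifluoromethyl ahead of fluoro, which favours a modest rise. The expected change is an estimated 2.3-fold higher number from compound 3 to compound 4 (0.36 log units; beyond the scatter) in this assay for this swap. For compound 4 the estimated value is 14000 nM with an expected range from 3000 nM to 60000 nM around it.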

Compound 4, concentration for 50% growth inhibition: 3010 nM
The estimate for compound 4 lay 4.7-fold (0.67 log units) above the measured number; low and high end bracket the measured number.
By their numbers in this assay, from the lowest: compound 4; then compound 3; then compound 2; then compound 1.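

In this assay, dimethylamino in place of trifluoromethyl gives a 2.0-fold lower number from compound 3 to compound 4 (0.31 log units; beyond the scatter) and so moves past the previous lowest number; the step is modest but beyond the scatter. Set against fluoro, the same group gives a 14-fold lower number from compound 2 to compound 4 (1.14 log units; beyond the scatter) as a large step, which widens the range seen at this place on the ring among compounds that all keep the hydroxy. Nothing here gives a measured reason for this order of end groups.

The compounds shown leave open whether a smaller amine, such as the unsubstituted amino group, or a ring amine such as morpholine would continue this trend. They also leave open how much of the gain from dimethylamino would remain in a compound without the hydroxy.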